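Bromo in place of hydrogen on compound 2

The source may report more compounds than this note shows. Statements on the series, on what has been measured and on what is new or still open speak of the compounds shown alone.

Measured so far:
compound 1 `N#Cc1cncc(N2C[C@@H]3CCNC[C@@H]32)c1`, a functional assay on HEK293 cells for agonist activity at Neuronal acetylcholine receptor; alpha4/beta2 (Homo sapiens), read by FLIPR; a lower number here means that less compound is needed, a higher number that more compound is needed for the effect: 2190 nM
compound 2 `N#Cc1cncc(N2C[C@H]3CCNC[C@H]32)c1`, this assay: 1930 nM

Among the measured compounds shown here, compound 2 stands lowest of the two numbers, but only just: the one measured step, a 1.1-fold lower number from compound 1 to compound 2 (0.05 log units; within the scatter), rests on the fact that compounds 1 and 2 differ only in the configuration as drawn and lies within the scatter, so the two compounds are not distinguished.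

Compound 3 `N#Cc1cc(N2C[C@H]3CCNC[C@H]32)cnc1Br` differs from compound 2 by bromo in place of hydrogen on an aromatic carbon. For the measured compounds named here, no measured step bears on this change; the single known step concerns configuration alone and is within the scatter, so it offers no guide to the bromo substitution. In this assay compound 3 is therefore expected near 1500 nM, within 400 nM to 6000 nM. The expected step is a 1.3-fold lower number from compound 2 to compound 3 (0.11 log units; within the scatter), with no direction beyond the scatter expected.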

Compound 3, half-maximal effective concentration: 172 nM
Compound 3: the middle estimate sits 8.7-fold (0.94 log units) above what was measured; measured number outside the range, below it.
By their numbers in this assay, from the lowest: compound 3; then compounds 2 and 1 (each within the scatter of the next).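

In this assay, bromo in place of hydrogen gives an 11-fold lower number from compound 2 to compound 3 (1.05 log units; beyond the scatter) and so marks this aromatic carbon, next to the ring nitrogen and ortho to a cyano group, as a place where one substituent moves the number beyond the scatter. Configuration alone had not separated compound 1 and compound 2. No measurement on these compounds gives a reason for the size of this step.

Open, going by these compounds, is whether chloro, methoxy or an amine on the same carbon would act as bromo does. Also open, on these data alone, is whether the mirror image of compound 3 would match compound 3.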